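Compound 2 to compound 4: shortening the hydroxycarbamoyl chain

The source may hold more compounds than are shown below. What is called first, only, known or untested is meant among the compounds shown, and "the series" means these compounds.

In a functional assay on MDA-MB-231 cells (Homo sapiens) for inhibition, read by MTT assay, with a stated time of 72 h (on this read-out lower numbers stand for stronger inhibition and higher numbers for weaker inhibition), compound 2 `Nc1ncnc2c1c(-c1cnc3[nH]ccc3c1)nn2CCCCCC(=O)NO` gives > 100000 nM, which is a limit of the assay and not a number. Any step away from compound 2 can therefore be read only against that limit.

Compound 4 `Nc1ncnc2c1c(-c1cnc3[nH]ccc3c1)nn2CCCC(=O)NO` keeps the core of compound 2 and differs only in the chain: hydroxycarbamoyl in place of 2-(hydroxycarbamoyl)ethyl on a saturated chain carbon, three bonds along the chain from an aromatic nitrogen. Hydroxycarbamoyl stands in place of 2-(hydroxycarbamoyl)ethyl on a saturated chain carbon, three bonds along the chain from an aromatic nitrogen, so 5-(hydroxycarbamoyl)pentyl becomes 3-(hydroxycarbamoyl)propyl.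

Among the measured compounds shown here, the only measured chain step comes from a different core. Compound 1 `Nc1nc2cc(-c3nn(CCCC(=O)NO)c4ncnc(N)c34)ccc2o1` carries the 3-(hydroxycarbamoyl)propyl chain and gives 19500 nM. With the core of compound 1 and a longer chain, compound 3 `Nc1nc2cc(-c3nn(CCCCCCCCC(=O)NO)c4ncnc(N)c34)ccc2o1` gives 30300 nM. That change amounts to a 1.6-fold higher number from compound 1 to compound 3 (0.19 log units; within the scatter).

On that single pair, no step beyond the scatter is expected for this shortening, in either direction, and a further report at the limit of the assay is quite possible. The expected step is a number no higher from compound 2 to compound 4 (the limit leaves the size open). For compound 4 the estimated value is 100000 nM, with an expected range of 40000 nM to 200000 nM.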

Compound 4, half-maximal inhibitory concentration: > 150000 nM
Compound 4 ended at the assay's limit; the forecaster's own chance of this, stated with the estimate: 60%; middle value at least 1.5-fold (0.17 log units) away from the limit.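

No step can be read from compound 2 to compound 4: in this assay each of the two carries only a limit of the assay and not a number. The compounds shown leave open whether 3-(hydroxycarbamoyl)propyl in place of 5-(hydroxycarbamoyl)pentyl changes the read-out at all on the core shared by compound 2 and compound 4.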